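Acetyl in Place of Ethoxy on a Shared Core

The source may report more compounds than this note shows. Statements on the series, on what has been measured and on what is new or still open speak of the compounds shown alone.

Compound 1, `COc1ccc(-c2ccc(NCc3ccccc3O)cc2)cc1`, gives 580 nM in a functional assay on Jurkat cells (Homo sapiens) for activation, with a stated time of 24 h; a lower number here means that less compound is needed, a higher number that more compound is needed for the effect.
Compound 2, `CCOc1ccc(-c2ccc(NCc3ccccc3O)cc2)cc1`, gives 520 nM in this assay.

Compound 2 stands at the low end of these two numbers, but the only gap to compare it with, a 1.1-fold lower number from compound 1 to compound 2 (0.05 log units; within the scatter), lies within the scatter, so the two compounds cannot be told apart on potency. That single measured step concerns only the chain on the oxygen.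

Compound 3, `CC(=O)c1ccc(-c2ccc(NCc3ccccc3O)cc2)cc1`, differs from compound 2 by acetyl in place of ethoxy on an aromatic carbon. Going by the values given here, no measured step swaps the oxygen-linked group for a carbonyl-bearing one, so nothing among the measured compounds bears directly on this change. The expectation therefore rests on the neighbouring value alone, with wide uncertainty and no direction favoured beyond the scatter. Compound 3 is estimated at 600 nM, with a range from 150 nM to 2500 nM. This corresponds to an expected step of a 1.2-fold higher number from compound 2 to compound 3 (0.06 log units; within the scatter).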

Compound 3, half-maximal effective concentration: "not active" (no number reported)
No number was reported for compound 3, so the estimate cannot be set against anything.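

Going by these compounds alone, compound 3 is reported as "not active" in this assay, with no number, so no step from compound 2 to compound 3 can be read. The compounds shown leave open how large a change acetyl in place of ethoxy brings on the shared core. No measurement shown here accounts for this result.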